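Adding a Bromine to the Phenyl Ring of Compound 2

This account rests on a few compounds, and the source may have more. Where it says the series, first, only, none or still open, it means among the compounds named here.

Of the compounds shown here, three share a core and have been tested in an assay for inhibition of 3-hydroxy-3-methylglutaryl-coenzyme A reductase (Rattus norvegicus), using microsomes; on this read-out lower numbers stand for stronger inhibition and higher numbers for weaker inhibition. Compound 1 `COC(=O)C[C@H](O)C[C@H](O)/C=C/n1c(-c2ccc(F)cc2)c(-c2ccc(F)cc2)c(Br)c1C(C)C` gives 0.3 nM in this assay. Compound 3 `COC(=O)C[C@H](O)C[C@H](O)/C=C/n1c(C(C)C)cc(-c2ccccc2)c1-c1ccc(F)cc1` gives 2 nM. Compound 2 `COC(=O)C[C@H](O)C[C@H](O)/C=C/n1c(C(C)C)cc(-c2ccc(F)cc2)c1-c1ccccc1` gives 25 nM, the highest of the three numbers, which here means the weakest inhibition. The distance from compound 2 to compound 3 is beyond the usual scatter of this assay, and the distance to compound 1 is larger still, so compound 2 is clearly the weakest of the measured set.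

Compound 4 `COC(=O)C[C@H](O)C[C@H](O)/C=C/n1c(C(C)C)cc(-c2ccc(F)cc2)c1-c1cccc(Br)c1` has not yet been measured. It differs from compound 2 in one place: bromo in place of hydrogen on an aromatic carbon, so that the phenyl group becomes a 3-bromophenyl group. Among the measured compounds shown here, no measured pair in this set shows exactly this change, so its size cannot be read from the data directly. For the measured compounds named here, the only guidance comes from compound 1, whose value of 0.3 nM shows that a bromine-bearing member of this series can reach strong inhibition, although its bromine sits on a different ring.

The expectation is a modest step toward stronger inhibition, a 1.7-fold lower number from compound 2 to compound 4 (0.22 log units; within the scatter), with wide uncertainty. Compound 4 is therefore estimated at 15 nM, within a range from 4 nM to 60 nM.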

Compound 4, half-maximal inhibitory concentration: 69 nM
The estimate for compound 4 lay 4.6-fold (0.66 log units) below the measured number, outside the stated range (above it).
By their numbers in this assay, from the lowest: compound 1; then compound 3; then compound 2; then compound 4.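

In this assay, bromo in place of hydrogen on the phenyl group gives a 2.8-fold higher number from compound 2 to compound 4 (0.44 log units; beyond the scatter), so at this position the added atom weakens inhibition rather than strengthening it, and the step lies beyond the usual scatter. Among the compounds shown here, this is the first direct reading of any single change in the set. Every earlier pair differed in more than one place. The change concerns an aromatic carbon meta to a large group. Nothing available speaks to the reason for the rise.

One step at one position cannot show whether the loss belongs to bromine itself or to this location on the ring, and a fluoro, chloro or methoxy group on the same carbon would help to separate those two readings, as would bromo elsewhere on the same ring. Going by these compounds, it also remains open whether a group of a different kind at this carbon, such as an amine or a carboxylic acid, would raise the number further, leave it unchanged or lower it.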